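The compounds below may be only part of what the source reports. "The series", "measured", "known", "first", "only" and "open" are said of these compounds alone.

In a functional assay on DLD-1 cells (Homo sapiens) for antiproliferative activity, read by CellTiter-Glo, with a stated time of 72 h (a lower number here means a stronger inhibitor, a higher number a weaker inhibitor), compound 1 (`Cc1cc(C)c(S(=O)(=O)N2CCN(C3CCN(C)CC3)CC2)c(C)c1`) gives 426 nM and compound 2 (`CC1CCN(C2CCN(S(=O)(=O)c3ccc(-c4ccccc4)cc3)CC2)CC1`) gives 258 nM (two values within the usual scatter of each other). Compound 3 (`CC1CCN(C2CCN(S(=O)(=O)c3ccc(OCc4ccccc4)cc3)CC2)CC1`) differs from compound 2 at one place: on an aromatic carbon, para to a large group, benzyloxy stands in place of phenyl (benzyloxy in place of phenyl on an aromatic carbon). Within the data shown here, no measured step in this small set shows what such a replacement does, so the expected step (a 1.2-fold higher number from compound 2 to compound 3 (0.07 log units; within the scatter)) in this assay is none beyond the scatter, in either direction. Compound 3 is estimated at 300 nM (expected range 120 nM to 750 nM).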

Compound 3, half-maximal inhibitory concentration: 385 nM
For compound 3 the middle estimate is 1.3-fold (0.11 log units) below the measured one, and the stated range covers the measured number.
By their numbers in this assay, from the lowest: compounds 2, 3 and 1 (each within the scatter of the next).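

In this assay, benzyloxy in place of phenyl on an aromatic carbon, para to a large group, gives a 1.5-fold higher number from compound 2 to compound 3 (0.17 log units; within the scatter). At this position, then, the two groups cannot be told apart in this assay, even though benzyloxy brings an oxygen and a hydrogen-bond acceptor that phenyl lacks. Nothing available explains this result.

Still open, on these data alone, is whether an amine, a carboxylic acid or a longer chain at this same aromatic carbon would shift the number beyond the scatter.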